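Swapping one five-membered aromatic ring on compound 2

A few compounds are considered here, and "the series" means these few. Any claim that something is new, unique, unknown or untested is made for them only; others in the source may bear on it.

Compound 1 `CC(C)c1ncc2c(N)c(C#N)c(N)nc2n1`: > 1000000 nM (a limit, not a number)
Compound 2 `CC(C)(C)c1nc(-c2cccs2)c2c(N)c(C#N)c(N)nc2n1`: 56000 nM

Both values come from a physicochemical assay for solubility, in phosphate buffer, with a stated time of 18 h; on this read-out lower numbers stand for lower solubility and higher numbers for higher solubility. Going by the values given here, compound 2 holds the only true number there, 56000 nM. The entry for compound 1 is a limit of the assay. Among the compounds with values here, no pair of measured compounds differs in just one place, so the next move rests on judgement.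

Compound 3 `Cc1c[nH]c(-c2nc(C(C)(C)C)nc3nc(N)c(C#N)c(N)c23)n1` keeps the core and the tert-butyl group of compound 2 and changes one group: 4-methyl-1H-imidazol-2-yl in place of thiophen-2-yl on an aromatic carbon. In words, 4-methyl-1H-imidazol-2-yl stands in place of thiophen-2-yl on an aromatic carbon. The expected move in this assay is upward, moderate in size and beyond the usual scatter, with wide uncertainty. The estimate is a 2.7-fold higher number from compound 2 to compound 3 (0.43 log units; beyond the scatter). For compound 3 the expected value is 150000 nM, with an estimated range of 30000 nM to 700000 nM.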

Compound 3, solubility: 5000 nM
Compound 3: middle estimate off by 30-fold (1.48 log units), on the high side, outside the stated range (below it).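

Going by these compounds alone, putting 4-methyl-1H-imidazol-2-yl in place of thiophen-2-yl gives an 11-fold lower number from compound 2 to compound 3 (1.05 log units; beyond the scatter) in this assay and this is the first pair to show that the read-out responds to a change at this aromatic carbon. The step is large even though one five-membered aromatic ring replaces another and neither group carries a net charge; the entering ring has a second hetero atom, a methyl group and a hydrogen-bond donor. Nothing in the data shown accounts for the direction or size of this step.

This single pair cannot divide the step among those features, so a plain 1H-imidazol-2-yl ring without the methyl group, or a phenyl ring at the same carbon, remains an open comparison. Also open, from the compounds shown here alone, is whether the same swap gives a similar step when a cyclopropyl group stands in place of the tert-butyl group.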